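The source may hold more compounds than are shown below. What is called first, only, known or untested is meant among the compounds shown, and "the series" means these compounds.

Working notes on the series. Among the measured compounds shown here, in a physicochemical assay for solubility, read by LC-MS, in phosphate buffer, with a stated time of 24 h, at pH 7.4 (a higher number here means a more soluble compound, a lower number a less soluble compound), compound 1 `Cc1ncc(-c2cnc(NCc3c(F)ccc4c3CCO4)c3cn[nH]c(=O)c23)n1C` gives 15000 nM and compound 2 `CN(C)C(=O)c1cc(-c2cnc(NCc3c(F)ccc4c3CCO4)c3cn[nH]c(=O)c23)n(C)n1` gives 3000 nM, the lower of the two numbers so far. Compound 3 `CN(c1ccn(C)n1)c1cnc(NCc2c(F)ccc3c2CCO3)c2cn[nH]c(=O)c12` carries methyl(1-methyl-1H-pyrazol-3-yl)amino in place of the 3-(dimethylcarbamoyl)-1-methyl-1H-pyrazol-5-yl of compound 2, on an aromatic carbon: methyl(1-methyl-1H-pyrazol-3-yl)amino in place of 3-(dimethylcarbamoyl)-1-methyl-1H-pyrazol-5-yl on an aromatic carbon. For the measured compounds named here, one measured step bears on this, at the same aromatic carbon: a 5.0-fold lower number from compound 1 to compound 2 (0.70 log units; beyond the scatter), modest and beyond the scatter. The group leaving now is the one that entered in that step, so a modest move back to a higher number is expected in this assay. Going by the values given here, the entering group has no measured precedent, so the expectation is loose. The estimated change is a 3.0-fold higher number from compound 2 to compound 3 (0.48 log units; beyond the scatter). For compound 3 the estimate is 9000 nM, with an expected range of 2500 nM to 30000 nM.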

Compound 3, solubility: 12000 nM
Compound 3: the middle estimate sits 1.3-fold (0.12 log units) below what was measured; the measured number falls inside the stated range.
By their numbers in this assay, from the lowest: compound 2; then compounds 3 and 1 (each within the scatter of the next).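

At this aromatic carbon in this assay, the lower number of compound 2 is not held by the other two groups: a 4.0-fold higher number from compound 2 to compound 3 (0.60 log units; beyond the scatter). Methyl(1-methyl-1H-pyrazol-3-yl)amino and 1,2-dimethyl-1H-imidazol-5-yl, which differ in ring and in the amino link to the core, read alike, with a 1.3-fold lower number from compound 1 to compound 3 (0.10 log units; within the scatter), so a high number here does not depend on either one of these two groups, and among the three compounds only compound 2 stands apart. Nothing on hand explains these numbers.

The compounds shown leave open whether the lower number of compound 2 goes with the dimethylcarbamoyl or with the pyrazole that carries it. A plain 1-methyl-1H-pyrazol-5-yl, or a carboxylic acid in place of the dimethylcarbamoyl, would separate the two.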